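The source may hold more compounds than are shown below. What is called first, only, known or untested is meant among the compounds shown, and "the series" means these compounds.

Three related compounds have so far been tested in a functional assay on A549 cells (Homo sapiens) for cytotoxicity, read by MTT assay, with a stated time of 24 h; a higher number here means a weaker inhibitor, a lower number a stronger inhibitor. Compound 1 `CC(=O)O[C@@]1(C)C/C=C2\O[C@H](C[C@@H]2C)C[C@]2(C)O[C@H]2C(=O)C(=C(C)C)CC1` gives > 50000 nM, which is a limit of the assay and not a number. Compound 2 `CC(C)=C1CC[C@]2(C)CC[C@]3(O[C@H](C[C@H]3C)C[C@]3(C)O[C@H]3C1=O)O2` gives > 50000 nM, which is also a limit and not a number. Among the compounds with values here, compound 3 `CC(=O)O[C@]1(C)CCC(=C(C)C)C(=O)[C@@H]2O[C@@]2(C)CC/C=C(\C)[C@H](O)CC1` gives 21500 nM, the only exact number in this small set. The overall picture is therefore dominated by the limit of > 50000 nM in this assay, at which 2 of the 3 values shown sit, and compound 2 has a limit rather than an exact position.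

Compound 4 `CC(C)=C1CC[C@]2(C)CC[C@]3(O[C@H](C[C@@H]3C)C[C@]3(C)O[C@H]3C1=O)O2` has not yet been measured, and it is a very close relative of compound 2: the two compounds have the same atoms and bonds and differ only in configuration as drawn: 1 of 6 stereo elements differ; a stereocentre at a saturated ring carbon is drawn R in compound 2 and S in compound 4. In other words, the atoms and bonds stay the same, while a stereocentre at a saturated ring carbon is drawn R in compound 2 and S in compound 4.

Within the data shown here, no measured pair here shows what such a change does in this assay. The expectation must therefore lean on compound 2, whose limit is > 50000 nM. The expected change is a number no higher from compound 2 to compound 4 (the limit leaves the size open), which means no shift in either direction beyond the usual scatter. For compound 4, the estimated value is 50000 nM, with an expected range from 25000 nM to 100000 nM, and the result may well be reported only as a limit.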

Compound 4, half-maximal inhibitory concentration: > 50000 nM
Compound 4 ended at the assay's limit (the forecaster's own chance of this, stated with the estimate: 75%); the middle value lies on the limit itself.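

In this assay compound 4 gives > 50000 nM and this is a limit of the assay, not a number. Within the data shown here, compound 2 sits at the same limit, so no step from compound 2 to compound 4 can be read: the limit of > 50000 nM in this assay, at which 3 of the 4 values shown sit. From the compounds shown here alone, whether this one stereocentre affects cytotoxicity at all stays open, with no exact value for either compound.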